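The source may hold more compounds than are shown below. What is called first, only, known or untested is meant among the compounds shown, and "the series" means these compounds.

Compound 1 `CCN1CCN(c2nc(C)nc3c2nc(-c2ccccc2Cl)n3C)CC1`: 88%
Compound 2 `Cc1nc(N2CCN(C)CC2)c2nc(-c3cccc(C(F)(F)F)c3)n(C3CCOCC3)c2n1`: 44%

Both compounds were tested in an ADME assay (liver) for metabolic stability, with Liver microsome (Canis lupus familiaris) as the target, read by LC-MS, using microsomes, with a stated time of 30 min, tested at 4 uM; a higher number here means that more of the compound is left, a lower number that less of the compound is left. Compound 2, at 44%, is the lower of the two, and its gap to compound 1 lies beyond the scatter. So compound 2 keeps a fair share of its starting amount but is clearly not at the level of compound 1.

The next compound, compound 3 `CCc1ccccc1-c1nc2c(N3CCN(C)CC3)nc(C)nc2n1C1CCOCC1`, has not been measured yet. It keeps the rest of compound 2 and changes one group: 2-ethylphenyl in place of 3-(trifluoromethyl)phenyl on an aromatic carbon. In words, 2-ethylphenyl takes the place of 3-(trifluoromethyl)phenyl on an aromatic carbon of the five-membered aromatic ring.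

For the measured compounds named here, no two measured compounds differ in one place only, so the data offer no direct guide to the size or direction of this swap. With no direction to go on, the expected change stays within the scatter: the estimate is a number 1 percentage points higher from compound 2 to compound 3 (within the scatter). Compound 1 at 88% shows how far values can spread in this series, so a wide range is expected. For compound 3 the estimated value is 45%, with an expected range of 22% to 70%.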

Compound 3, percent of the compound remaining: 74%
For compound 3 the middle estimate is 29 percentage points below the measured one, outside the stated range (above it).
By their numbers in this assay, from the lowest: compound 2; then compound 3; then compound 1.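

In this assay, placing 2-ethylphenyl instead of 3-(trifluoromethyl)phenyl on the aromatic carbon of the five-membered ring gives a number 30 percentage points higher from compound 2 to compound 3 (beyond the scatter), so the group on this carbon clearly matters for how much compound is left. For the compounds shown here, this is the first comparison here in which only one place differs: the oxan-4-yl group, the methylpiperazine and the rest of the shared core stay the same, so the shift belongs to this swap alone, something the first two compounds, which differ in more than one place, could not show. Nothing measured here accounts for the rise.

The swap changes both the substituent on the phenyl ring and where it sits, so this single step cannot separate the two, and a plain phenyl, a methoxyphenyl or a phenyl bearing a nitrile at this carbon would be needed to tell how far the result depends on the ethyl group itself. From the compounds shown here alone, it also remains open whether the same swap would give a similar step with a different group in place of the oxan-4-yl group, such as a simple methyl or a longer alkyl chain.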